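This account rests on a few compounds, and the source may have more. Where it says the series, first, only, none or still open, it means among the compounds named here.

Working notes on the series built on the core of compound 1 `COc1ccc([C@@H]2CC(=O)c3cc(CC=C(C)C)c(OC)cc3O2)cc1`, read in a functional assay on A549 cells (Homo sapiens) for inhibition, read by sulforhodamine B assay, with a stated time of 48 h, tested at 50 uM; a higher number here means more inhibition of growth at the concentration tested, a lower number less inhibition of growth. Here compound 1 gives 45%, compound 2 `COc1cc2c(cc1CC=C(C)C)C(=O)C[C@@H](c1ccc(Oc3cccc([N+](=O)[O-])c3)cc1)O2` gives 37%, and compound 3 `CCCCOc1ccc([C@@H]2CC(=O)c3cc(CC=C(C)C)c(OC)cc3O2)cc1` gives 37%, level with compound 2, all three within the scatter of each other.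

The next change leads to compound 4 `C#CCOc1ccc([C@@H]2CC(=O)c3cc(CC=C(C)C)c(OC)cc3O2)cc1`: ethynyl in place of propyl on a saturated chain carbon bound to an oxygen on an aromatic ring, that is, butoxy to propargyloxy.

Three measured steps change the group on this oxygen: a number 8 percentage points lower from compound 1 to compound 3 (within the scatter), a number 8 percentage points lower from compound 1 to compound 2 (within the scatter) and no change at the digits printed from compound 2 to compound 3 (within the scatter). None leaves the scatter, so no step beyond the scatter is expected in this assay.

The expected step is a number 3 percentage points higher from compound 3 to compound 4 (within the scatter). Compound 4 is estimated at 40%, with a range of 28% to 52%.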

Compound 4, percent growth inhibition at one concentration: 53%
For compound 4 the middle estimate is 13 percentage points below the measured one, outside the stated range (above it).
By their numbers in this assay, from the lowest: compounds 2, 3, 1 and 4 (each within the scatter of the next, the first and the last beyond it).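

In this assay the group on this oxygen now gives steps beyond the scatter, with propargyl set apart from butyl (a number 16 percentage points higher from compound 3 to compound 4 (beyond the scatter)) and from 3-nitrophenyl (a number 16 percentage points higher from compound 2 to compound 4 (beyond the scatter)). Against methyl the change stays within the scatter (a number 8 percentage points higher from compound 1 to compound 4 (within the scatter)), so propargyl and methyl cannot be ordered. Nothing available bears on why propargyl stands apart from butyl.

Whether the triple bond or the length of the chain accounts for the step remains open, and a propyl or allyl group on this oxygen would separate the two. Going by these compounds, how an amine or a carboxylic acid at the end of the chain would read also remains open.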